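Halogen swap on a shared core: cytotoxicity in breast epithelial cells

The compounds below may be only part of what the source reports. "The series", "measured", "known", "first", "only" and "open" are said of these compounds alone.

Measured compounds:
compound 1, `O=C1C(=O)N(CN2CCN(c3ccnc4cc(Cl)ccc34)CC2)c2cc(Cl)ccc21`: 47500 nM
compound 2, `O=C1C(=O)N(CN2CCN(c3ccnc4cc(Cl)ccc34)CC2)c2cc(Br)ccc21`: 33200 nM
compound 3, `NC(=S)N/N=C1/C(=O)N(CN2CCN(c3ccnc4cc(C(F)(F)F)ccc34)CC2)c2cc(Cl)ccc21`: 20100 nM

In an ADME assay on 184B5 cells (Homo sapiens) for cytotoxicity, read by sulforhodamine B assay, with a stated time of 48 h (a higher number here means a weaker inhibitor of growth, a lower number a stronger inhibitor of growth), compound 1 and compound 2 differ only in one place, (bromo in place of chloro on an aromatic carbon), and the step of a 1.4-fold lower number from compound 1 to compound 2 (0.16 log units; within the scatter) lies within the scatter, so no order can be read from those two. Compound 3 carries a different core; the difference between the core of compound 3 and that of compound 1 is not broken down here. Compound 3 gives the lowest of the three numbers, yet its gap to compound 2 is within the scatter, while its gap to compound 1 is beyond it.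

Compound 4, `NC(=S)N/N=C1/C(=O)N(CN2CCN(c3ccnc4cc(C(F)(F)F)ccc34)CC2)c2cc(Br)ccc21`, is not yet measured. It differs from compound 3 by bromo in place of chloro on an aromatic carbon, the same change as from compound 1 to compound 2, at a place described in the same words. The step of a 1.3-fold lower number from compound 3 to compound 4 (0.13 log units; within the scatter) is therefore expected to be of about the same small size as a 1.4-fold lower number from compound 1 to compound 2 (0.16 log units; within the scatter), since that single measured instance is all that is known of this change. Compound 4 is expected to give 15000 nM, most likely between 7000 nM and 32000 nM.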

Compound 4, concentration for 50% growth inhibition: 21400 nM
Beside the measured number, compound 4's estimate is 1.4-fold (0.15 log units) below it, and the stated range covers the measured number.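

In this assay, bromo in place of chloro on an aromatic carbon has now been followed on two cores, and the new step, a 1.1-fold higher number from compound 3 to compound 4 (0.03 log units; within the scatter), is small, as the earlier one was: the same change on two cores in this assay, a 1.4-fold lower number (0.16 log units; within the scatter) from compound 1 to compound 2 and a 1.1-fold higher number (0.03 log units; within the scatter) from compound 3 to compound 4, 1.5-fold (0.18 log units) apart, within the scatter of two such steps. Within these four compounds, the change therefore carries from the core of compound 1 to the core of compound 3 with no sign that the two cores treat it differently. This does not show that bromo and chloro are interchangeable in general, and with both steps inside the scatter it fixes neither a direction nor a size for the change, nor does it say how the change would behave on a third core.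

The compounds shown leave open how other groups would read at that aromatic carbon, such as fluoro, methoxy, an amine or a carboxylic acid. They also leave open whether the change would stay this small on a core carrying a nitrile or a longer chain.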